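The source may report more compounds than this note shows. Statements on the series, on what has been measured and on what is new or still open speak of the compounds shown alone.

Compound 3 `CC#CCN(CC[C@H](N)C(=O)O)C[C@H]1O[C@@H](n2cnc3c(N)ncnc32)[C@H](O)[C@@H]1O` gives 61.3% in an assay for inhibition of tRNA (cytosine(38)-C(5))-methyltransferase (Homo sapiens), with a stated time of 5 min, tested at 100 uM (a higher number here means more inhibition at the concentration tested (going by the name of the read-out), a lower number less inhibition), the highest of the three numbers measured. Compound 2 `CC(C)N(CC[C@H](N)C(=O)O)C[C@H]1O[C@@H](n2cnc3c(N)ncnc32)[C@H](O)[C@@H]1O` gives 44% and compound 1 `CN(CC[C@H](N)C(=O)O)C[C@H]1O[C@@H](n2cnc3c(N)ncnc32)[C@H](O)[C@@H]1O` gives 30.3%. Both steps into compound 3 were beyond the scatter: a number 31 percentage points higher from compound 1 to compound 3 (beyond the scatter) and a number 17.3 percentage points higher from compound 2 to compound 3 (beyond the scatter). Compound 4 `C#CCCN(CC[C@H](N)C(=O)O)C[C@H]1O[C@@H](n2cnc3c(N)ncnc32)[C@H](O)[C@@H]1O` differs from compound 3 as propargyl in place of prop-1-yn-1-yl on a saturated chain carbon bound to an amine nitrogen; the two have the same atoms, joined differently. For the measured compounds named here, no measured step shifts the triple bond at constant atom count, so those steps bear on it only loosely: they compare the whole but-2-yn-1-yl chain against hydrogen or isopropyl, not one bond moved within it. In this assay a step of a number 6.3 percentage points lower from compound 3 to compound 4 (within the scatter) is expected, inside the scatter. Compound 4 is estimated at 55%, range 40% to 70%.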

Compound 4, a percentage reported as inhibition, at one concentration (the size of the read-out at that concentration, not a potency): 30.2%
Beside the measured number, compound 4's estimate is 24.8 percentage points above it, and the stated range ends above it.
By their numbers in this assay, from the lowest: compounds 4 and 1 (each within the scatter of the next); then compound 2; then compound 3.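

In this assay the shift from but-2-yn-1-yl to but-3-yn-1-yl gives a number 31.1 percentage points lower from compound 3 to compound 4 (beyond the scatter) with the same atoms, so on this amine nitrogen the place of the triple bond within the chain matters, not only its presence. With a number 13.8 percentage points lower from compound 2 to compound 4 (beyond the scatter) this chain falls under isopropyl, and with a number 0.1 percentage points lower from compound 1 to compound 4 (within the scatter) it shows no gain over methyl, so a triple bond in the chain does not by itself raise the read-out. Nothing at hand accounts for this gap.

Open, as far as these compounds go, is whether the gain needs an internal triple bond or only a longer chain. A pent-2-yn-1-yl or but-2-en-1-yl group on the same nitrogen would separate these.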